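This account rests on a few compounds, and the source may have more. Where it says the series, first, only, none or still open, it means among the compounds named here.

Series notes. In a functional assay on prostate cells (Homo sapiens) for antiproliferative activity (on this read-out lower numbers stand for stronger inhibition of growth and higher numbers for weaker inhibition of growth), compound 2 `Cc1cn2c(/C=N/NC(=N)N)c(-c3cccnc3)nc2s1` gives 6920 nM. Compound 1 `Cc1cn2c(/C=N/NC(=N)N)c(-c3ccncc3)nc2s1` carries pyridin-4-yl in place of pyridin-3-yl on an aromatic carbon, and in this assay compound 1 gives 17400 nM; the step is a 2.5-fold higher number from compound 2 to compound 1 (0.40 log units; beyond the scatter). Compound 3 `N=C(N)N/N=C/c1c(-c2cccnc2)nc2sc(Cl)cn12` differs from compound 2 in the core by chloro in place of methyl on an aromatic carbon, and in this assay compound 3 gives 15100 nM, a step of a 2.2-fold higher number from compound 2 to compound 3 (0.34 log units; beyond the scatter). Compound 4 `N=C(N)N/N=C/c1c(-c2ccncc2)nc2sc(Cl)cn12` is not yet measured; it relates to compound 3 as compound 1 relates to compound 2, by pyridin-4-yl in place of pyridin-3-yl on an aromatic carbon, and the place is described in the same words both times, so it is the same change made on the chloro core instead of the methyl core. Among the compounds shown the change appears twice, once measured. Compound 3 stands near compound 1 and well above compound 2. Among the compounds with values here, the expected step for compound 4 in this assay is a 2.3-fold higher number from compound 3 to compound 4 (0.37 log units; beyond the scatter), set beside the measured one on the methyl core, because the only guide is a 2.5-fold higher number from compound 2 to compound 1 (0.40 log units; beyond the scatter) and the cores differ only by chloro in place of methyl on an aromatic carbon, whose own step was modest. Going by these compounds, whether the change carries over to the chloro core is untested. Compound 4 is estimated at 35000 nM in this assay, with a range from 15000 nM to 80000 nM.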

Compound 4, concentration for 50% growth inhibition: 17400 nM
For compound 4 the middle estimate is 2.0-fold (0.30 log units) above the measured one, within the range that was stated.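

In this assay, pyridin-4-yl in place of pyridin-3-yl on the chloro core gives a 1.2-fold higher number from compound 3 to compound 4 (0.06 log units; within the scatter), and the change read on both cores does not separate: the same change on two cores in this assay, a 2.5-fold higher number (0.40 log units; beyond the scatter) from compound 2 to compound 1 and a 1.2-fold higher number (0.06 log units; within the scatter) from compound 3 to compound 4, 2.2-fold (0.34 log units) apart, within the scatter of two such steps

Chloro in place of methyl, read with pyridin-4-yl in the molecule, gives no change at the digits printed from compound 1 to compound 4 (within the scatter), and this change does not separate between the two pyridine groups either: the same change on two cores in this assay, a 2.2-fold higher number (0.34 log units; beyond the scatter) from compound 2 to compound 3 and no change at the digits printed (within the scatter) from compound 1 to compound 4, 2.2-fold (0.34 log units) apart, within the scatter of two such steps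

Within the data shown here, the four compounds therefore fit a carry-over of either change from one core to the other, but they do not show that the step keeps its size, since the pyridine change lies beyond the scatter on the methyl core and within it on the chloro core, and each core offers only a single pair.

Still open, going by these compounds, is how a phenyl or pyridin-2-yl group in place of the pyridine ring would behave on either core. Equally open, on these data alone, is whether a bromo or trifluoromethyl group in place of chloro or methyl would leave the pyridine step as it stands here.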